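The compounds below may be only part of what the source reports. "The series", "measured", "known", "first", "only" and "open" are said of these compounds alone.

Of the compounds shown here, three in one series have been tested in a functional assay on SK-BR-3 cells (Homo sapiens) for inhibition, read by CellTiter-Glo, with a stated time of 72 h (a lower number here means a stronger inhibitor, a higher number a weaker inhibitor), and a fourth awaits its result. Compound 1 `CC(C)c1nn(-c2ccc(C(N)=O)c(N[C@H]3CC[C@H](O)CC3)c2)c2nccc(-n3cnc(-c4ccc(Oc5ccccc5)cc4)c3)c12` carries a 4-(4-phenoxyphenyl)imidazolyl group on the shared core; in this assay compound 1 gives 503 nM. Compound 2 `CC(C)c1nn(-c2ccc(C(N)=O)c(N[C@H]3CC[C@H](O)CC3)c2)c2nccc(-c3ccoc3)c12` carries a furan-3-yl group in that position. For compound 2 this assay reports only a limit, > 10000 nM. Compound 3 `CC(C)c1nn(-c2ccc(C(N)=O)c(N[C@H]3CC[C@H](O)CC3)c2)c2nccc(-c3ccc4ccccc4c3)c12` carries a naphthalen-2-yl group. For compound 3 as well the result is only a limit, > 10000 nM. The step that the two limits leave unreadable from compound 2 to compound 3 therefore cannot be read, because both results sit at the limit of > 10000 nM in this assay, at which 2 of the 3 values shown sit. Compound 3 thus stands at the weak end of what has been measured, its true value unknown beyond that limit.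

Compound 4 `CC(C)c1nn(-c2ccc(C(N)=O)c(N[C@H]3CC[C@H](O)CC3)c2)c2nccc(-n3cnc(-c4ccccc4)c3)c12` differs from compound 3 by 4-phenyl-1H-imidazol-1-yl in place of naphthalen-2-yl on an aromatic carbon. Within the data shown here, no measured step covers this change, so the expectation rests on the neighbouring values. For compound 3 this assay reports only a limit. Compound 1, which carries the same imidazolyl group extended by a phenoxy substituent, gives 503 nM in this assay. Compound 4 is expected to fall between these, estimated at 2500 nM, in a range from 600 nM to 10000 nM. The estimated step of an at least 4.0-fold lower number from compound 3 to compound 4 (0.60 log units; beyond the scatter) starts from a limit, so its size is expected but not certain.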

Compound 4, half-maximal inhibitory concentration: 276 nM
Compound 4: middle estimate off by 9.1-fold (0.96 log units), on the high side; the whole stated range lies above it.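

In this assay, the 4-phenyl-1H-imidazol-1-yl group on this aromatic carbon, opposite the ring nitrogen, sets itself clearly apart from furan-3-yl and from naphthalen-2-yl, which also has two aromatic rings, so two rings alone do not account for the result: the change gives an at least 36-fold lower number from compound 3 to compound 4 (1.55 log units; beyond the scatter) and an at least 36-fold lower number from compound 2 to compound 4 (1.55 log units; beyond the scatter). Compound 2 and compound 3 each have only a limit and not a number, so these two steps give minimum sizes: the limit of > 10000 nM in this assay, at which 2 of the 4 values shown sit. The phenoxy group of compound 1 also proves not to be required for activity at this level, since the comparison gives a 1.8-fold lower number from compound 1 to compound 4 (0.26 log units; within the scatter), and the two compounds cannot be ranked.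

The compounds shown leave open whether the imidazole ring alone, without its phenyl group, would keep this activity. Also open, from the compounds shown here alone, is how a morpholine or a carboxylic acid on that phenyl ring, in place of phenoxy, would read in this assay.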